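The source may hold more compounds than are shown below. What is called first, only, known or untested is meant among the compounds shown, and "the series" means these compounds.

Working notes on the series. In an assay on Sf9 cells for inhibition of protein deacetylase HDAC6 (Homo sapiens), read by fluorescence, with a stated time of 40 min, tested at 100 nM (on this read-out lower numbers stand for less inhibition and higher numbers for more inhibition at the one concentration tested (going by the name of the read-out)), compound 2 `CCc1ccc(-c2nc(CNc3ccc(C(=O)NO)cc3)n(-c3ccccc3)n2)cc1` gives 54.6%, and compound 1 `O=C(NO)c1ccc(NCc2nc(-c3ccc(Br)o3)nn2-c2ccccc2)cc1` gives 55.8%; the two numbers lie within the scatter of each other, so compound 2 is not set apart from compound 1 on this assay. The next compound, compound 3 `Cc1ccsc1-c1nc(CNc2ccc(C(=O)NO)cc2)n(-c2ccccc2)n1`, differs from compound 2 by 3-methylthiophen-2-yl in place of 4-ethylphenyl on an aromatic carbon. Among the measured compounds shown here, the one step that bears on this exchange of the aryl group at the same position is a number 1.2 percentage points lower from compound 1 to compound 2 (within the scatter), which stayed within the scatter. No change beyond the scatter is therefore expected here, and compound 3 is estimated at 55%, range 40% to 70%, an expected step of a number 0.4 percentage points higher from compound 2 to compound 3 (within the scatter).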

Compound 3, a percentage reported as inhibition, at one concentration (the size of the read-out at that concentration, not a potency): 72.1%
The estimate for compound 3 lay 17.1 percentage points below the measured number; the measured number lies above the stated range.
By their numbers in this assay, from the lowest: compounds 2 and 1 (each within the scatter of the next); then compound 3.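

The aryl group at this position is not interchangeable: 3-methylthiophen-2-yl gives a number 17.5 percentage points higher from compound 2 to compound 3 (beyond the scatter) in place of 4-ethylphenyl, and a number 16.3 percentage points higher from compound 1 to compound 3 (beyond the scatter) in place of 5-bromofuran-2-yl. An exchange on this aromatic carbon can therefore move the read-out beyond the scatter, which the earlier pair did not show. Nothing at hand accounts for this step. Going by these compounds, whether the rise follows the thiophene ring or its methyl group stays open, as does the effect of an unsubstituted thiophene, an aminomethyl group or a carboxylic acid at this position.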